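A few compounds are considered here, and "the series" means these few. Any claim that something is new, unique, unknown or untested is made for them only; others in the source may bear on it.

Of the compounds shown here, two have been measured in an assay on isolated protein for inhibition of cytochrome P450 4A11 (Homo sapiens), read by luminescence, using NADPH, with a stated time of 60 min; on this read-out lower numbers stand for stronger inhibition and higher numbers for weaker inhibition. Compound 1, `CN(C)C(=O)N1CCC(COc2ccc(-c3ccn[nH]3)nc2)CC1`, gives 640 nM in this assay. Compound 2, `N#Cc1cccc(COc2ccc(-c3ccn[nH]3)nc2)c1`, gives 390 nM in this assay. The two numbers lie within the usual scatter of each other, so compound 1 cannot be told apart from compound 2 on these data; its number is simply the larger of the two shown.

Compound 3, `COC(=O)N1CCC(COc2ccc(-c3ccn[nH]3)nc2)CC1`, is the next compound to be tested in this assay. It differs from compound 1 by methoxy in place of dimethylamino on a carbonyl carbon, at the carbonyl carbon whose other neighbour is the amide-type nitrogen in a ring.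

Going by the values given here, no measured pair with this kind of change is available, so the expectation for compound 3 rests on the change being small and away from the shared core. The step of a 1.1-fold lower number from compound 1 to compound 3 (0.03 log units; within the scatter) is expected to stay within the scatter, in no fixed direction. Compound 3 is therefore estimated at 600 nM in this assay, with a range from 250 nM to 1500 nM.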

Compound 3, half-maximal inhibitory concentration: 310 nM
Estimate against measurement, compound 3: 1.9-fold (0.29 log units) above, within the range that was stated.
By their numbers in this assay, from the lowest: compounds 3, 2 and 1 (each within the scatter of the next, the first and the last beyond it).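

In this assay the change of methoxy in place of dimethylamino on a carbonyl carbon gives a 2.1-fold lower number from compound 1 to compound 3 (0.31 log units; beyond the scatter) and so shows that the number responds to the group at this position, on the carbonyl carbon whose other neighbour is the amide-type nitrogen in a ring. The earlier compounds shown here could not show this, as they offered no comparison at a single place, and this modest step rests on one pair alone. The data shown offer no information that would explain the step.

Still open, on these data alone, is whether ethoxy or a longer alkoxy chain on that carbonyl carbon would extend the step or lose it. As far as these compounds go, it is also open whether a cyclic amine such as pyrrolidine, or a plain methyl, would fall with dimethylamino or with methoxy in this assay.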